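The source may report more compounds than this note shows. Statements on the series, on what has been measured and on what is new or still open speak of the compounds shown alone.

Within the data shown here, in a functional assay on TSGH cells (Homo sapiens) for inhibition, with a stated time of 72 h (a higher number here means a weaker inhibitor, a lower number a stronger inhibitor), compound 1 `CCn1ccc2cc(C(=O)c3cc(OC)c(OC)c(OC)c3)ccc21` gives 41 nM, while compound 2 `CCCn1ccc2cc(C(=O)c3cc(OC)c(OC)c(OC)c3)ccc21` gives 1500 nM, the higher of the two numbers so far. Compound 3 `COc1cc(C(=O)c2ccc3c(ccn3C(C)C)c2)cc(OC)c1OC` has not yet been measured. It differs from compound 2 as follows: isopropyl in place of propyl on an aromatic nitrogen. The two have the same atoms, joined differently, with isopropyl in place of propyl on an aromatic nitrogen.

Among the measured compounds shown here, only one measured step bears on this change. It lies in the same substituent on the aromatic nitrogen and is large: a 37-fold higher number from compound 1 to compound 2 (1.56 log units; beyond the scatter). That step shows that this assay can respond strongly to a small change in this group, but no branched substituent has been measured, so its transfer to compound 3 is uncertain. Given the lower number of compound 1 at 41 nM, a partial move back in that direction is expected, not a full return. The expected change is a 3.8-fold lower number from compound 2 to compound 3 (0.57 log units; beyond the scatter), a moderate step towards a lower number. For compound 3 the estimated value is 400 nM, with an expected range of 80 nM to 2000 nM.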

Compound 3, half-maximal inhibitory concentration: 1100 nM
Estimate against measurement, compound 3: 2.8-fold (0.44 log units) below, within the range that was stated.
By their numbers in this assay, from the lowest: compound 1; then compounds 3 and 2 (each within the scatter of the next).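

In this assay, among these compounds, the exchange of propyl for isopropyl on an aromatic nitrogen gives a 1.4-fold lower number from compound 2 to compound 3 (0.13 log units; within the scatter) and so leaves compound 2 and compound 3 indistinguishable, a reading that the single earlier step could not supply. With a 27-fold higher number from compound 1 to compound 3 (1.43 log units; beyond the scatter) as a second large step alongside a 37-fold higher number from compound 1 to compound 2 (1.56 log units; beyond the scatter), the gap to compound 1 now holds for both the unbranched and the branched group, so within these three compounds, where none goes against it, isopropyl does not bring the number back towards that of compound 1. Nothing available here explains either the large steps or the absence of a difference between propyl and isopropyl.

The compounds shown leave open whether the number stays at this level or moves further with a longer chain such as butyl or with a ring such as cyclopropyl on the aromatic nitrogen. Also open, going by these compounds, is how methyl or a bare nitrogen-hydrogen would compare with compound 1, and whether a chain carrying a hydroxyl or an amine would fall with compound 1 or with compound 2 and compound 3.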